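Cutting the hexyl chain of compound 3 to allyl

This account rests on a few compounds, and the source may have more. Where it says the series, first, only, none or still open, it means among the compounds named here.

Values in a functional assay on MDA-MB-231 cells (Homo sapiens), read by microscopy and transwell migration, with a stated time of 24 h; on this read-out lower numbers stand for stronger inhibition and higher numbers for weaker inhibition:
- compound 1 `CCCn1c(-c2ccc(C)cc2C)cs/c1=N\C(=O)c1ccccc1`: 292 nM
- compound 2 `CCCCn1c(-c2ccc(C)cc2C)cs/c1=N\C(=O)c1ccccc1`: 196 nM
- compound 3 `CCCCCCn1c(-c2ccc(C)cc2C)cs/c1=N\C(=O)c1ccccc1`: 45 nM

Compound 3 has the lowest number of the three, and its gaps to the other two lie beyond the scatter. The next structure is compound 4 `C=CCn1c(-c2ccc(C)cc2C)cs/c1=N\C(=O)c1ccccc1`, and the change is vinyl in place of pentyl on a saturated chain carbon bound to an aromatic nitrogen. The same difference reads hexyl to allyl. Among the measured compounds, longer chains gave lower numbers: a 1.5-fold lower number from compound 1 to compound 2 (0.17 log units; within the scatter), a 4.4-fold lower number from compound 2 to compound 3 (0.64 log units; beyond the scatter) and, overall, a 6.5-fold lower number from compound 1 to compound 3 (0.81 log units; beyond the scatter). Allyl is close in length to the propyl of compound 1, which gives 292 nM. Going by the values given here, no measured compound has a double bond in this chain, so that part is untested. A rise of similar size is therefore expected in this assay, an estimated 6.2-fold higher number from compound 3 to compound 4 (0.79 log units; beyond the scatter). The estimate for compound 4 is 280 nM, with an expected range of 110 nM to 650 nM.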

Compound 4, half-maximal inhibitory concentration: 456 nM
Beside the measured number, compound 4's estimate is 1.6-fold (0.21 log units) below it; measured number inside the range.
By their numbers in this assay, from the lowest: compound 3; then compounds 2, 1 and 4 (each within the scatter of the next, the first and the last beyond it).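

In this assay this is the largest change seen at this position: cutting hexyl to allyl gives a 10-fold higher number from compound 3 to compound 4 (1.01 log units; beyond the scatter) and wipes out the gain of the long chain. The comparison with the butyl chain gives a 2.3-fold higher number from compound 2 to compound 4 (0.37 log units; beyond the scatter) while the comparison with the propyl chain gives a 1.6-fold higher number from compound 1 to compound 4 (0.19 log units; within the scatter) so the double bond shows no separation from the saturated chain of nearly the same length. Nothing available explains these differences.

Going by these compounds, whether an octyl chain would lower the number further remains open. So does the effect of a double bond within a longer chain, or of an amine at the chain end.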